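Shortening the Butoxy Chain of Compound 1

This account rests on a few compounds, and the source may have more. Where it says the series, first, only, none or still open, it means among the compounds named here.

For the measured compounds named here, in a physicochemical assay for lipophilicity, in phosphate buffer, measured as octanol-water partition, at pH 11.5 (on this read-out higher numbers stand for higher lipophilicity and lower numbers for lower lipophilicity), compound 1 (`CCCCOC(=N)NC(=N)Nc1ccc(Cl)cc1`) gives 3.32 as the lowest of the three numbers measured so far. Compound 3 (`N=C(NCCCCCCNC(=N)NC(=N)Nc1cccc(C(F)(F)F)c1)NC(=N)Nc1cccc(C(F)(F)F)c1`) stands nearest with 5.12 and compound 2 (`CCCCSc1ccc(NC(=N)NC(=N)NCCCCCCNC(=N)NC(=N)Nc2ccc(SCCCC)cc2)cc1`) stands furthest with 7.58 and both gaps lie beyond the scatter of repeated measurements. No two of these three compounds differ in one place only, so they offer no measured step to reason from.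

Compound 4 (`CCOC(=N)NC(=N)Nc1ccc(Cl)cc1`) has yet to be measured. It differs from compound 1 at a single site (hydrogen in place of ethyl on a saturated chain carbon, two bonds along the chain from an oxygen on an unsaturated carbon). Hydrogen stands in place of ethyl on a saturated chain carbon, two bonds along the chain from an oxygen on an unsaturated carbon, which turns butoxy into ethoxy.

Going by the values given here, with no measured step for this change, the expectation rests on the structural change alone, with compound 1 at 3.32 as the starting point. A downward step beyond the scatter is expected in this assay for the shorter chain. The estimated step is a number 1.02 log units lower from compound 1 to compound 4 (beyond the scatter) and a number lower than that of the parent is the expected direction. The estimate for compound 4 is 2.3 (expected range 1.9 to 2.7).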

Compound 4, partition coefficient: 2.32
The estimate for compound 4 lay 0.02 log units below the measured number; low and high end bracket the measured number.
By their numbers in this assay, from the lowest: compound 4; then compound 1; then compound 3; then compound 2.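

For the compounds shown here, the pair of compound 1 and compound 4 gives the first measured step in this set: in this assay, hydrogen in place of ethyl, which turns butoxy into ethoxy, gives a number 1.00 log units lower from compound 1 to compound 4 (beyond the scatter) and so places a measured change at a single site. The earlier compounds shown here could show only how far apart their numbers lay, as none of them differed from another in one place only. Here the rest of the core of compound 1 stays the same, so the change in the number goes with this site alone, on a saturated chain carbon, two bonds along the chain from an oxygen on an unsaturated carbon, although nothing given here bears on what lies behind the step.

With only butoxy and ethoxy at this site, the compounds shown do not tell whether a methoxy group or a longer chain such as hexyloxy would continue the same trend in this assay or break from it. They also leave open whether an amine or a carboxylic acid at the end of the chain would move the number in the same direction, and whether the same shortening would give a step of similar size on another core.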